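This account rests on a few compounds, and the source may have more. Where it says the series, first, only, none or still open, it means among the compounds named here.

Measured in a functional assay on MCF7 cells (Homo sapiens) for cytotoxicity, read by MTT assay, with a stated time of 24 h, tested at 0.64 ug/mL; a lower number here means a weaker effect, a higher number a stronger effect of the compound at the concentration tested:

- compound 1 `Cn1c(-c2ccc(NC(=O)CSc3nc4ccccc4o3)cc2)nc(-c2ccccc2)c1-c1ccccc1`: 18.7%
- compound 2 `Cn1nnnc1SCC(=O)Nc1ccc(-c2nc(-c3ccccc3)c(-c3ccccc3)n2C)cc1`: 21.9%
- compound 3 `Cc1nnc(SCC(=O)Nc2ccc(-c3nc(-c4ccccc4)c(-c4ccccc4)n3C)cc2)s1`: 35.1%

The three share one core and differ only in the group attached to the sulfur of the side chain. Compound 3 stands highest of the three: its step from compound 2 is a number 13.2 percentage points higher from compound 2 to compound 3 (beyond the scatter) and its step from compound 1 is a number 16.4 percentage points higher from compound 1 to compound 3 (beyond the scatter), both beyond the scatter, while the step from compound 1 to compound 2 is a number 3.2 percentage points higher from compound 1 to compound 2 (within the scatter), within the scatter.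

Compound 4 `Cn1c(-c2ccc(NC(=O)CSC3=NCCS3)cc2)nc(-c2ccccc2)c1-c1ccccc1` is not yet measured. It differs from compound 3 in this way: a group of 5 heavy atoms (3 carbon, 1 nitrogen, 1 sulfur; one five-membered non-aromatic ring with 2 hetero atoms) in place of a group of 6 heavy atoms (3 carbon, 2 nitrogen, 1 sulfur; one five-membered aromatic ring with 3 hetero atoms), on a sulfur

Both measured steps that lead into compound 3 bear on this change, since each swaps the group on that sulfur; both raised the number by a modest amount. Compound 4 leaves the group that gave the highest value for one not seen among the measured compounds. For the measured compounds named here, there is no measured step with a non-aromatic ring at this position, so the direction rests only on the fact that every other group there gave a lower number than compound 3. A modest fall is therefore expected, and for compound 4 the expected step is a number 10.1 percentage points lower from compound 3 to compound 4 (beyond the scatter). The estimate for compound 4 in this assay is 25%, with a range from 12% to 38%.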

Compound 4, a percentage reported as activity, at one concentration (the size of the read-out at that concentration, not a potency): 10.3%
Estimate against measurement, compound 4: 14.7 percentage points above, and the stated range ends above it.
By their numbers in this assay, from the lowest: compounds 4, 1 and 2 (each within the scatter of the next, the first and the last beyond it); then compound 3.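

For the compounds shown here, this is the first non-aromatic ring on the sulfur, and in this assay putting it in place of the 5-methyl-1,3,4-thiadiazol-2-yl group gives a number 24.8 percentage points lower from compound 3 to compound 4 (beyond the scatter), a larger fall than the one the earlier compounds suggested, which confirms compound 3 as the highest of the four. Against the 1-methyl-1H-tetrazol-5-yl group of compound 2, the same ring gives a number 11.6 percentage points lower from compound 2 to compound 4 (beyond the scatter), but against the 1,3-benzoxazol-2-yl group of compound 1 it gives a number 8.4 percentage points lower from compound 1 to compound 4 (within the scatter), so compound 1 goes against any rule that aromatic rings at this place outperform a non-aromatic one. Nothing measured here explains these differences.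

Going by these compounds alone, still open is whether a 1,3,4-thiadiazol-2-yl ring without its methyl group would keep the number of compound 3, or whether a saturated ring other than the one in compound 4 would behave the same way. Also open, on these data alone, is what a plain ethyl chain or a carboxylic acid on this sulfur would give, and how these steps would look at other concentrations, as each number here comes from a single tested concentration.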